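The source may report more compounds than this note shows. Statements on the series, on what has been measured and on what is new or still open speak of the compounds shown alone.

Compound 1 `COc1ccc(C(=O)Nc2cc(Br)cc3c(=O)cc(C(=O)O)oc23)c(Cl)c1` and compound 2 `Cc1cccc(C(=O)Nc2cc(Cl)cc3c(=O)cc(C(=O)O)oc23)c1` share one core and were both tested in an assay on CHO cells for agonist activity at G protein-coupled receptor GPR35 (Rattus norvegicus), read by a beta-galactosidase reporter and beta-arrestin recruitment, with a stated time of 90 min (a lower number here means that less compound is needed, a higher number that more compound is needed for the effect), where compound 1 gives 4170 nM and compound 2 gives 2100 nM. Compound 1 has the higher of the two numbers, but the two values lie within the usual scatter of each other, so no order between them can be claimed. Compound 3 `COc1ccc(C(=O)Nc2cc(Br)cc3c(=O)cc(C(=O)O)oc23)cn1` differs from compound 1 by one change: 6-methoxypyridin-3-yl in place of 2-chloro-4-methoxyphenyl on a carbonyl carbon. Among the compounds with values here, no comparable step has been measured here, so the size of the change is open; the expected step from compound 1 to compound 3 is a 1.2-fold higher number from compound 1 to compound 3 (0.08 log units; within the scatter), a step not clearly beyond the scatter. Compound 3 is therefore expected to give about 5000 nM, estimated between 1500 nM and 16000 nM.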

Compound 3, half-maximal effective concentration: 991 nM
Estimate against measurement, compound 3: 5.0-fold (0.70 log units) above, outside the stated range (below it).
By their numbers in this assay, from the lowest: compound 3; then compounds 2 and 1 (each within the scatter of the next).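

Putting 6-methoxypyridin-3-yl in place of 2-chloro-4-methoxyphenyl on a carbonyl carbon gives a 4.2-fold lower number from compound 1 to compound 3 (0.62 log units; beyond the scatter), so the group at this position can clearly shift how much compound is needed. Compound 1 and compound 2 differ in more than one place, so they could not show this. Nothing available here explains the step.

This single change removes the chlorine and also brings a nitrogen into the ring, and the compounds shown do not separate the two. On these data alone, how a plain 4-methoxyphenyl group on that carbonyl carbon would compare stays open.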